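Methyl on the Amine Nitrogen of a Reduced Amide Series

The compounds below may be only part of what the source reports. "The series", "measured", "known", "first", "only" and "open" are said of these compounds alone.

Measured compounds in an assay for inhibition of Amine oxidase [flavin-containing] A (Bos taurus), read by fluorescence; a lower number here means a stronger inhibitor, a higher number a weaker inhibitor:
compound 1, `Cn1c(C(=O)Nc2ccccc2)cc2ccccc21`, 10000 nM
compound 2, `CN(C(=O)c1cc2ccccc2n1C)c1ccccc1`, 15 nM
compound 3, `Cn1c(CNc2ccccc2)cc2ccccc21`, 10 nM

Compound 1 and compound 2 share one core and differ by methyl in place of hydrogen on an amide-type nitrogen. That change gives a 670-fold lower number from compound 1 to compound 2 (2.82 log units; beyond the scatter). Compound 3 carries a different core; how the core of compound 3 differs from the core of compound 1 is not broken down here. In this assay compound 3 and compound 2 lie within the scatter of each other, and both sit far from compound 1.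

Compound 4, `CN(Cc1cc2ccccc2n1C)c1ccccc1`, is not yet measured. It differs from compound 3 by methyl in place of hydrogen on a nitrogen on an aromatic ring. For the measured compounds named here, this is the same kind of change as the one from compound 1 to compound 2, but the place is not the same: in the earlier pair the nitrogen is an amide-type nitrogen whose other neighbours are aromatic carbon and carbonyl carbon, whereas here it is a nitrogen on an aromatic ring whose other neighbours are aromatic carbon and saturated chain carbon. Going by the values given here, the only measured step of this kind is the large one from compound 1 to compound 2, so the direction is taken from it, but the size is taken with caution, since compound 3 already gives 10 nM and the same drop again would be unusual. Compound 4 is therefore expected at 6 nM, with a likely range of 1.5 nM to 25 nM. The step that this estimate means is a 1.7-fold lower number from compound 3 to compound 4 (0.22 log units; within the scatter).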

Compound 4, inhibition constant: 6 nM
Estimate against measurement, compound 4: no gap at the digits printed; the measured number falls inside the stated range.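

In this assay, for the compounds shown here, methyl in place of hydrogen on a nitrogen on an aromatic ring gives a 1.7-fold lower number from compound 3 to compound 4 (0.22 log units; within the scatter), so on this core the change produces no step that can be told from the scatter. Set beside the same kind of change on an amide-type nitrogen, the size of the step does not carry from one core to the other: the same change on two cores in this assay, a 670-fold lower number (2.82 log units; beyond the scatter) from compound 1 to compound 2 and a 1.7-fold lower number (0.22 log units; within the scatter) from compound 3 to compound 4, 400-fold (2.60 log units) apart, beyond the scatter of two such steps. Going by these compounds alone, only two cores are compared, and the neighbours of the nitrogen differ with the core. Compound 1 starts from 10000 nM and compound 3 starts from 10 nM. These two pairs cannot separate the core from the starting value.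

As far as these compounds go, it remains open whether a third core would follow the large step, the small one or neither. From the compounds shown here alone, it is also open how an ethyl group or a longer chain in place of the methyl on this nitrogen would read in this assay, and whether the small step on the core of compound 3 would hold for such groups.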